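The source may hold more compounds than are shown below. What is called first, only, known or untested is meant among the compounds shown, and "the series" means these compounds.

Compound 1 `CCOc1c(-c2occ(C)c2C(=O)OC)ccc2c(CC)cccc12` gives 1.2 ug/mL in a functional assay on MDA-MB-231 cells (Homo sapiens) for cytotoxicity, read by MTT assay, with a stated time of 72 h; a higher number here means that more compound is needed for the effect, a lower number that less compound is needed. Compound 2 `CCc1cccc2c(OC)c(-c3occ(C)c3CO)ccc12` is known in this assay only as a limit, > 10 ug/mL, and so stands without a number (the limit of > 10 ug/mL in this assay, at which 1 of the 2 values shown sits). Compound 1 and compound 2 differ in two places, so their values are not read as a single step. Compound 3 `CCOc1c(-c2occ(C)c2CO)ccc2c(CC)cccc12` carries the change (methyl in place of hydrogen on a saturated chain carbon bound to an oxygen on an aromatic ring). With no measured step of this kind in the series, a step of no more than the usual scatter is expected, in no fixed direction. The step that the limit leaves unreadable from compound 2 to compound 3 is the expected one. Compound 3 is therefore expected at 12 ug/mL, within 4 ug/mL to 40 ug/mL, and most likely again reported only as a limit.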

Compound 3, concentration for half-maximal effect: 1.4 ug/mL
Compound 3: middle estimate off by 8.6-fold (0.93 log units), on the high side; measured number outside the range, below it.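

In this assay, methoxy to ethoxy gives an at least 7.1-fold lower number from compound 2 to compound 3 (0.85 log units; beyond the scatter) and so shows that this position responds to the change beyond the scatter. The size of that step is bounded on one side only, since compound 2 is held at a limit: the limit of > 10 ug/mL in this assay, at which 1 of the 3 values shown sits. With ethoxy in place, hydroxymethyl in place of methoxycarbonyl on an aromatic carbon gives a 1.2-fold higher number from compound 1 to compound 3 (0.07 log units; within the scatter) and so separates neither group from the other here. Open, as far as these compounds go, is whether a longer chain such as propoxy keeps the value of compound 3, and whether a carboxylic acid on that aromatic carbon fits the same reading.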